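From cyano to bromo: a tolerance question

The source may report more compounds than this note shows. Statements on the series, on what has been measured and on what is new or still open speak of the compounds shown alone.

- Compound 1: `Cc1cc(C#N)cc(C)c1Oc1ccc(N)c(Nc2ccc(C#N)cc2)n1`, 8980 nM
- Compound 2: `Cc1cc(/C=C/C#N)cc(C)c1Oc1ccc([N+](=O)[O-])c(Nc2ccc(C#N)cc2)c1`, > 48700 nM

Within the data shown here, in an ADME assay on TZM cells (Homo sapiens) for cytotoxicity, read by XTT assay, with a stated time of 4 days (a lower number here means that less compound is tolerated, a higher number that more compound is tolerated), compound 1 gives 8980 nM, the only exact number available so far. Compound 2 stands at > 48700 nM, which is a limit of the assay and not a number.

Compound 3 `Cc1cc(Br)cc(C)c1Oc1ccc(N)c(Nc2ccc(C#N)cc2)n1` changes compound 1 in one place, with bromo in place of cyano on an aromatic carbon. Among the measured compounds shown here, no measured pair shows this swap, so only a step within the scatter is expected, in no firm direction: the estimated 1.1-fold lower number from compound 1 to compound 3 (0.05 log units; within the scatter). For compound 3 the expected value in this assay is 8000 nM, with an estimated range from 2500 nM to 30000 nM.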

Compound 3, half-maximal cytotoxic concentration: 15500 nM
Beside the measured number, compound 3's estimate is 1.9-fold (0.29 log units) below it; the range from low to high includes it.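

In this assay, among these compounds, the first pair here that differs in one place shows that bromo in place of cyano, on an aromatic carbon para to a large group, gives a 1.7-fold higher number from compound 1 to compound 3 (0.24 log units; within the scatter) and so no change that can be told from the scatter. At this position, then, the nitrile and its hydrogen-bond acceptor can be lost without a clear shift in tolerance. Nothing measured here bears on a cause for this result.

As far as these compounds go, whether a very different group at this position, such as an amine or a carboxylic acid, would leave the tolerance as it is stays open. One swap on one core also cannot show whether the same holds elsewhere.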